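Thiophene for Phenyl in a Bile Acid Receptor Series

A few compounds are considered here, and "the series" means these few. Any claim that something is new, unique, unknown or untested is made for them only; others in the source may bear on it.

Three compounds have been measured in an assay on isolated protein for agonist activity at Bile acid receptor (Homo sapiens), read by AlphaScreen, with a stated time of 30 min; a lower number here means a smaller maximal response, a higher number a larger maximal response:
Compound 1 `Cc1ccccc1-n1nc(C)c2c1NC(=O)[C@H](C)S[C@@H]2c1ccc(-c2ccccc2)cc1` gives 24%.
Compound 2 `COc1ccccc1-n1nc(C)c2c1NC(=O)[C@H](C)S[C@@H]2c1ccc(Oc2ccccc2)cc1` gives 37%.
Compound 3 `Cc1ccc(-n2nc(C)c3c2NC(=O)[C@H](C)S[C@@H]3c2ccc(Oc3ccccc3)cc2)cc1` gives 11%.

Compound 1 stands second highest of the three in this assay: compound 2 lies above it by more than the scatter, and compound 3 lies below it by more than the scatter. Among the compounds with values here, the only single-site step available, a number 26 percentage points lower from compound 2 to compound 3 (beyond the scatter), concerns the group on the aromatic nitrogen and does not touch the position changed in compound 4 `Cc1ccccc1-n1nc(C)c2c1NC(=O)[C@H](C)S[C@@H]2c1ccc(-c2ccsc2)cc1`, where (thiophen-3-yl in place of phenyl on an aromatic carbon). Within the data shown here, no measured step bears on this change, so the expectation rests on compound 1 alone, and no movement beyond the scatter in this assay is anticipated. The expected step, a number 1 percentage points higher from compound 1 to compound 4 (within the scatter), is accordingly small. Compound 4 is estimated at 25%, within 10% to 40%.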

Compound 4, largest response reached (reported as efficacy), in percent of the reference or control that the assay uses: 68%
Beside the measured number, compound 4's estimate is 43 percentage points below it, outside the stated range (above it).
By their numbers in this assay, from the lowest: compound 3; then compound 1; then compound 2; then compound 4.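

In this assay, exchanging phenyl for thiophen-3-yl, on an aromatic carbon para to a large group, gives a number 44 percentage points higher from compound 1 to compound 4 (beyond the scatter). Within the data shown here, this position, which no earlier step touched, is therefore sensitive to the aromatic ring it carries, and a five-membered ring with one hetero atom gives a far larger maximal response here than the six-membered carbon ring. Nothing at hand accounts for this gain. Going by these compounds, it remains open whether thiophen-2-yl or pyridin-3-yl at this position would match thiophen-3-yl. On these data alone, it is also open whether 2-methoxyphenyl on the aromatic nitrogen would add to the gain.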